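Adding a sulfonyl group to compound 2

A few compounds are considered here, and "the series" means these few. Any claim that something is new, unique, unknown or untested is made for them only; others in the source may bear on it.

Values in a functional assay on A549 cells (Homo sapiens) for antiproliferative activity, read by MTT assay, with a stated time of 24 h; a lower number here means a stronger inhibitor, a higher number a weaker inhibitor:
- compound 1 `Cc1ccc(-c2nn(-c3ccccc3)cc2-c2nc3ccccc3[nH]2)cc1`: 4010 nM
- compound 2 `FC(F)(F)c1ccc(-c2nn(-c3ccccc3)cc2-c2nc3ccccc3[nH]2)cc1`: 3620 nM
- compound 3 `O=[N+]([O-])c1ccc(S(=O)(=O)n2c(-c3cn(-c4ccccc4)nc3-c3ccc(F)cc3)nc3ccccc32)cc1`: 1030 nM

Compound 2 lies within the scatter of compound 1, and both show higher numbers than compound 3. Compound 4 `Cc1ccc(C)c(S(=O)(=O)n2c(-c3cn(-c4ccccc4)nc3-c3ccc(C(F)(F)F)cc3)nc3ccccc32)c1` follows from compound 2 through ((2,5-dimethylphenyl)sulfonyl in place of hydrogen on an aromatic nitrogen), with (2,5-dimethylphenyl)sulfonyl in place of hydrogen on an aromatic nitrogen. Going by the values given here, the only measured single-place step, a 1.1-fold lower number from compound 1 to compound 2 (0.04 log units; within the scatter), swaps methyl for trifluoromethyl and does not touch that nitrogen, so it gives no guide to size. Among the compounds with values here, compound 3, at 1030 nM, is the only measured compound with a sulfonyl group there, though it also differs elsewhere. A lower number is therefore expected in this assay, an estimated 2.6-fold lower number from compound 2 to compound 4 (0.41 log units; beyond the scatter). For compound 4 the expected value is 1400 nM, with an estimated range of 450 nM to 3800 nM.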

Compound 4, half-maximal inhibitory concentration: 150 nM
For compound 4 the middle estimate is 9.3-fold (0.97 log units) above the measured one; the measured number lies below the stated range.
By their numbers in this assay, from the lowest: compound 4; then compound 3; then compounds 2 and 1 (each within the scatter of the next).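

In this assay, the hydrogen on this aromatic nitrogen is not required for a low number: (2,5-dimethylphenyl)sulfonyl in its place gives a 24-fold lower number from compound 2 to compound 4 (1.38 log units; beyond the scatter). This is the only single-place step shown at this nitrogen, and it shows that substitution here can change the number by far more than the scatter. No available measurement explains the size of this step.

On these data alone, it remains open whether the sulfonyl link or the dimethylphenyl ring accounts for the step; methylsulfonyl or benzoyl on the same nitrogen would separate the two.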